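Swapping a halogenated bicycle for a nitrogen-bearing one

The compounds below may be only part of what the source reports. "The series", "measured", "known", "first", "only" and "open" are said of these compounds alone.

Measured compounds:
compound 1 `O=C(Nc1ccc(-n2ncc3c(Br)cccc32)cc1)Nc1ccc(Cl)c(C(F)(F)F)c1`: 1300 nM
compound 2 `O=C(Nc1ccc(-n2ncc3c(C(F)(F)F)cccc32)cc1)Nc1ccc(C(F)(F)F)cc1`: 800 nM
compound 3 `O=C(Nc1ccc(-n2ncc3c(Cl)cccc32)cc1)Nc1ccc(C(F)(F)F)cc1`: 6800 nM

All three were tested in a functional assay on NCI-H460 cells (Homo sapiens) for cytotoxicity, read by MTT assay, with a stated time of 72 h; a lower number here means a stronger inhibitor, a higher number a weaker inhibitor. Compound 1 stands second highest of the three numbers; its value and that of compound 2 lie within the scatter of each other, while compound 3 gives a clearly higher number. Compound 4 `O=C(Nc1ccc(-n2ncc3cccnc32)cc1)Nc1ccc(Cl)c(C(F)(F)F)c1` differs from compound 1 by a group of 9 heavy atoms (6 carbon, 3 nitrogen; one five-membered aromatic ring with 2 hetero atoms, one six-membered aromatic ring with 1 hetero atom) in place of a group of 10 heavy atoms (7 carbon, 2 nitrogen, 1 bromine; one five-membered aromatic ring with 2 hetero atoms, one six-membered aromatic ring of carbon only), on an aromatic carbon. Going by the values given here, no measured pair makes exactly this exchange. The nearest guide is the change on the same ring region, an 8.5-fold higher number from compound 2 to compound 3 (0.93 log units; beyond the scatter), which shows that altering that part of the molecule can shift the number modestly. Removing the bromine altogether and changing the ring is a larger move, so a somewhat weaker result is expected, as a 2.3-fold higher number from compound 1 to compound 4 (0.36 log units; beyond the scatter). Compound 4 is therefore estimated at 3000 nM, in the range 900 nM to 12000 nM.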

Compound 4, half-maximal inhibitory concentration: 16600 nM
Compound 4: middle estimate off by 5.5-fold (0.74 log units), on the low side; the measured number lies above the stated range.
By their numbers in this assay, from the lowest: compounds 2 and 1 (each within the scatter of the next); then compound 3; then compound 4.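

Replacing the 4-bromo-1H-indazol-1-yl group of compound 1 with the group in compound 4 gives a 13-fold higher number from compound 1 to compound 4 (1.11 log units; beyond the scatter) in this assay. The earlier compounds shown here showed that changing the substituent on this bicycle can move the number, whereas this step shows that losing the bromine while putting a hetero atom into the six-membered ring can cost much activity. Nothing measured here explains the drop.

The two parts of the change occur together, so their separate contributions cannot be told apart. Going by these compounds, how an amine or a methoxy group would fare in place of the bromine also remains open.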